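The source may report more compounds than this note shows. Statements on the series, on what has been measured and on what is new or still open speak of the compounds shown alone.

Measured compounds in an assay on isolated protein for inhibition of DNA topoisomerase 1 (Homo sapiens), with a stated time of 30 min, tested at 100 uM; a higher number here means a stronger effect of the compound at the concentration tested, a lower number a weaker effect:
Compound 1, `Oc1ccc(-c2cc(-c3cccc(Cl)c3)nc(-c3cccs3)c2)cc1`, gives 52.4%.
Compound 2, `Oc1ccc(-c2cc(-c3ccc(Cl)cc3)nc(-c3ccsc3)c2)cc1`, gives 47.7%.
Compound 3, `Oc1cccc(-c2cc(-c3ccsc3)nc(-c3cccc(Cl)c3)c2)c1`, gives 26.2%.

Compound 3 stands lowest of the three numbers; the nearest is compound 2, whose value lies beyond the scatter above it, and compound 1 sits further above still. Compound 4, `Oc1ccc(-c2cc(-c3ccsc3)nc(-c3cccc(Cl)c3)c2)cc1`, is not yet measured. It differs from compound 3 in one place: 4-hydroxyphenyl in place of 3-hydroxyphenyl on an aromatic carbon. Compounds 1 and 2 both carry 4-hydroxyphenyl and both sit well above compound 3, so the step is expected to be upward and beyond the scatter in this assay. For compound 4 an inhibition of 48% is expected, between 33% and 62%, the step of a number 21.8 percentage points higher from compound 3 to compound 4 (beyond the scatter) being the estimate, because compound 1 gives 52.4% and compound 2 gives 47.7%.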

Compound 4, a percentage reported as inhibition, at one concentration (the size of the read-out at that concentration, not a potency): 26%
Compound 4: middle estimate off by 22 percentage points, on the high side, outside the stated range (below it).
By their numbers in this assay, from the lowest: compounds 4 and 3 (each within the scatter of the next); then compounds 2 and 1 (each within the scatter of the next).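

In this assay, 4-hydroxyphenyl in place of 3-hydroxyphenyl opposite the ring nitrogen leaves the read-out unmoved in this setting (a number 0.2 percentage points lower from compound 3 to compound 4 (within the scatter)), so this swap alone does not account for the higher numbers of compounds 1 and 2. With 4-hydroxyphenyl held fixed, the larger steps come with the other two groups: 3-chlorophenyl in place of 4-chlorophenyl (a number 21.7 percentage points lower from compound 2 to compound 4 (beyond the scatter)) and thiophen-3-yl in place of thiophen-2-yl (a number 26.4 percentage points lower from compound 1 to compound 4 (beyond the scatter)). No available evidence bears on these steps.

Open, on these data alone, is whether the hydroxyl position matters alongside 4-chlorophenyl or thiophen-2-yl. Also open, as far as these compounds go, is how an amine or a methoxy group in place of the hydroxyl would read.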